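The source may hold more compounds than are shown below. What is called first, only, known or untested is meant among the compounds shown, and "the series" means these compounds.

Measured compounds:
- compound 1, `COc1ccc(S(=O)(=O)NCCCCCCNCc2ccc(Br)cc2)cc1`: 13000 nM
- compound 2, `CC(C)c1ccc(S(=O)(=O)NCCCCCCNCc2ccc(Br)cc2)cc1`: 5730 nM
- compound 3, `Cc1ccc(C)c(S(=O)(=O)NCCCCCCNCc2ccc(Br)cc2)c1`: 12000 nM

All three share one core and differ only in the aryl group on the sulfonyl sulfur. In a functional assay on MIA PaCa-2 cells (Homo sapiens) for inhibition, read by MTT assay, with a stated time of 72 h (on this read-out higher numbers stand for weaker inhibition of growth and lower numbers for stronger inhibition of growth), compound 3 gives the second highest of the three numbers. Its nearest neighbour is compound 1, with a 1.1-fold lower number from compound 1 to compound 3 (0.03 log units; within the scatter). The step from compound 2 is larger, a 2.1-fold higher number from compound 2 to compound 3 (0.32 log units; beyond the scatter), and is the only one of the three shown steps on this aryl group that goes beyond the scatter; the step of a 2.3-fold lower number from compound 1 to compound 2 (0.36 log units; beyond the scatter) is of the same modest size.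

Compound 4, `O=[N+]([O-])c1ccccc1S(=O)(=O)NCCCCCCNCc1ccc(Br)cc1`, has not been measured. It carries 2-nitrophenyl in place of 2,5-dimethylphenyl on a sulfonyl sulfur. Both earlier exchanges of this aryl group bear on it, and neither moved this assay by more than a modest amount. Compound 4 is therefore expected to sit close to compound 3, with at most a modest step in either direction, estimated as no change at the digits printed from compound 3 to compound 4 (within the scatter). The estimate for compound 4 in this assay is 12000 nM, expected to fall between 5000 nM and 30000 nM.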

Compound 4, concentration for 50% growth inhibition: 11700 nM
The estimate for compound 4 lay 1.0-fold (0.01 log units) above the measured number; low and high end bracket the measured number.
By their numbers in this assay, from the lowest: compound 2; then compounds 4, 3 and 1 (each within the scatter of the next).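

In this assay, 2-nitrophenyl on the sulfonyl sulfur, with 2 hydrogen-bond acceptors, takes the place of 2,5-dimethylphenyl, with 0, and the number stays within the scatter, a 1.0-fold lower number from compound 3 to compound 4 (0.01 log units; within the scatter). Compound 4 also stays within the scatter of the 4-methoxyphenyl compound, a 1.1-fold lower number from compound 1 to compound 4 (0.05 log units; within the scatter), while the modest step of a 2.0-fold higher number from compound 2 to compound 4 (0.31 log units; beyond the scatter) goes beyond it, so among these four aryl groups only the 4-isopropylphenyl of compound 2 stands apart. Nothing measured here offers a reason for this insensitivity to the change of aryl group.

Going by these compounds, whether an amine or a carboxylic acid on the aryl ring would keep the number in this range remains open. So does whether a longer chain in the shared core would move these compounds together or separate them.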